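Phenylsulfanyl in place of benzothiophene on the aromatic carbon

The compounds below may be only part of what the source reports. "The series", "measured", "known", "first", "only" and "open" are said of these compounds alone.

Within the data shown here, compound 2 `CCOC(=O)c1cnc(-c2cc3ccccc3s2)nc1NN1C(=O)C=C(C)C1=O` stands highest of the two numbers so far: in a functional assay on Jurkat cells for inhibition of nuclear factor NF-kappa-B complex (Homo sapiens) (a higher number here means a weaker inhibitor, a lower number a stronger inhibitor), compound 2 gives 4000 nM, whereas compound 1 `CCOC(=O)c1cnc(-c2ccc(Cl)s2)nc1NN1C(=O)C=C(C)C1=O` gives 300 nM. Among the measured compounds shown here, the single measured step, a 13-fold higher number from compound 1 to compound 2 (1.12 log units; beyond the scatter), came with 1-benzothiophen-2-yl in place of 5-chlorothiophen-2-yl on an aromatic carbon. Compound 3 `CCOC(=O)c1cnc(Sc2ccccc2)nc1NN1C(=O)C=C(C)C1=O` differs from compound 2 by phenylsulfanyl in place of 1-benzothiophen-2-yl on an aromatic carbon. The measured step bears on the present one only loosely: it shows that the group on this aromatic carbon moves the number strongly, and that the larger two-ring group of compound 2 gave the higher number. Phenylsulfanyl is neither of those groups, and no step with it is known in this assay. The expectation is a lower number for compound 3 than for compound 2, a 2.7-fold lower number from compound 2 to compound 3 (0.43 log units; beyond the scatter), with wide uncertainty. Compound 3 is estimated at 1500 nM, with a range of 300 nM to 8000 nM.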

Compound 3, half-maximal inhibitory concentration: 1000 nM
For compound 3 the middle estimate is 1.5-fold (0.18 log units) above the measured one; the measured number falls inside the stated range.
By their numbers in this assay, from the lowest: compound 1; then compound 3; then compound 2.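

In this assay, the aromatic carbon between two ring nitrogen atoms accepts a group joined through sulfur: phenylsulfanyl in place of 1-benzothiophen-2-yl gives a 4.0-fold lower number from compound 2 to compound 3 (0.60 log units; beyond the scatter) and so recovers part of the loss seen with the two-ring group. The 5-chlorothiophen-2-yl group still holds the lowest number of the three, and phenylsulfanyl in its place gives a 3.3-fold higher number from compound 1 to compound 3 (0.52 log units; beyond the scatter) at this position. No measurement available here accounts for either step.

The step between compound 2 and compound 3 changes both the ring and its link to the core, so the share of each stays unresolved. Also open, going by these compounds, is how an amine such as morpholine, a directly attached phenyl or a 4-chlorophenylsulfanyl group would behave on this carbon.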